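The compounds below may be only part of what the source reports. "The series", "measured", "known", "first", "only" and "open" are said of these compounds alone.

Compound 3 `Cc1ccncc1S(=O)(=O)NC[C@@H](O)CN1CCC[C@@]2(CCN(c3ncnc(N)c3C3CC3)C2)C1` carries a 4-methylpyridin-3-yl group on its sulfonyl sulfur; in an assay on LNCaP cells for inhibition of RAC-alpha serine/threonine-protein kinase (Homo sapiens) (a higher number here means a weaker inhibitor, a lower number a stronger inhibitor), compound 3 gives "not determined" (no result reported), so it stands on no number at all. The nearest measured relatives are compound 1 `Nc1ncnc(N2CC[C@@]3(CCCN(C[C@H](O)CNS(=O)(=O)c4ccccc4Br)C3)C2)c1C1CC1`, which in this assay gives 2000 nM, and compound 2 `Cc1cc(F)ccc1S(=O)(=O)NC[C@@H](O)CN1CCC[C@@]2(CCN(c3ncnc(N)c3C3CC3)C2)C1`, which gives 2200 nM; the step of a 1.1-fold higher number from compound 1 to compound 2 (0.04 log units; within the scatter) shows that exchanging one aryl group for another on the sulfonyl sulfur left the number within the scatter. Compound 4 `Cc1noc(C)c1S(=O)(=O)NC[C@@H](O)CN1CCC[C@@]2(CCN(c3ncnc(N)c3C3CC3)C2)C1` differs from compound 3 by 3,5-dimethyl-1,2-oxazol-4-yl in place of 4-methylpyridin-3-yl on a sulfonyl sulfur. Among the measured compounds shown here, no measured step covers this exchange, so the only guide is that small aryl step, and the number for compound 4 in this assay is expected to lie near those of compounds 1 and 2, with no shift beyond the scatter foreseen. Compound 4 is estimated at 2500 nM, with a range from 1000 nM to 7000 nM.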

Compound 4, half-maximal inhibitory concentration: 490 nM
For compound 4 the middle estimate is 5.1-fold (0.71 log units) above the measured one, and the stated range ends above it.
By their numbers in this assay, from the lowest: compound 4; then compounds 1 and 2 (each within the scatter of the next).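

At the sulfonyl sulfur, the choice of aromatic group can move the number in this assay beyond the scatter: with 3,5-dimethyl-1,2-oxazol-4-yl there is a 4.5-fold lower number from compound 2 to compound 4 (0.65 log units; beyond the scatter), and a 4.1-fold lower number from compound 1 to compound 4 (0.61 log units; beyond the scatter). The earlier exchange between two substituted phenyl groups had shown no such shift. No available evidence explains this difference.

With no result for compound 3, its exchange with compound 4 cannot be read. As far as these compounds go, whether the lower number depends on the two methyl groups also stays open, as does how an unsubstituted 1,2-oxazol-4-yl or a 1,3-dimethylpyrazol-4-yl group would behave here.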